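Swapping an amino-acid amide for a morpholine amide

A few compounds are considered here, and "the series" means these few. Any claim that something is new, unique, unknown or untested is made for them only; others in the source may bear on it.

Measured compounds:
compound 1, `CNC(=O)/C=C/c1ccncc1-c1ccc2ccccc2c1`, 12.4 nM
compound 2, `CC(C)[C@@H](NC(=O)/C=C/c1ccncc1-c1ccc2ccccc2c1)C(=O)O`, "not determined" (no result reported)

All three compounds share one core, a pyridine carrying a naphthyl group and a double-bonded chain ending in a carbonyl; they differ only in what sits on that carbonyl. In an assay on a protein complex for inhibition of CDK8/Cyclin C (Homo sapiens), with a stated time of 1 h (on this read-out higher numbers stand for weaker inhibition and lower numbers for stronger inhibition), compound 1, with a methylamino group on the carbonyl, gives 12.4 nM. Compound 2 carries a (1-carboxy-2-methylpropyl)amino group in the same position, and for compound 2 the outcome in this assay is "not determined" (no result reported), so no number stands for it and nothing can be said of where it lies against compound 1.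

Compound 3, `O=C(/C=C/c1ccncc1-c1ccc2ccccc2c1)N1CCOCC1`, is the next step: morpholin-4-yl in place of (1-carboxy-2-methylpropyl)amino on a carbonyl carbon. Among the measured compounds shown here, because compound 2 has no value, the size of this step cannot be measured, and no comparable step among the measured compounds exists to lean on. For the measured compounds named here, the only anchor is compound 1 with 12.4 nM, a compound that also keeps an amide hydrogen, which compound 3 does not. With that anchor, compound 3 is expected to give about 40 nM, within a range of 8 nM to 250 nM.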

Compound 3, half-maximal inhibitory concentration: 60.3 nM
For compound 3 the middle estimate is 1.5-fold (0.18 log units) below the measured one; measured number inside the range.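

Among the compounds shown here, at this position, the carbonyl carbon, the compounds now give a first readable step in this assay: going from methylamino to morpholin-4-yl produces a 4.9-fold higher number from compound 1 to compound 3 (0.69 log units; beyond the scatter). The loss of inhibition is modest but real, as the step lies beyond the usual scatter of repeated measurements. Compound 3 still gives 60.3 nM, so a six-membered non-aromatic ring on this carbonyl, with no amide hydrogen left, does not abolish inhibition in this read-out. Compound 2 has no number, so its step to compound 3 cannot be read, and nothing measured here accounts for the size of the step from methylamino to morpholin-4-yl.

The compounds shown do not separate the effect of adding a ring from the effect of removing the amide hydrogen, and a dimethylamino group, which has no ring and no amide hydrogen, would help to pull those two apart. From the compounds shown here alone, it also remains open how a piperidine ring, which lacks the ring oxygen of morpholine, or a longer chain in place of methylamino would read in this assay.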